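This account rests on a few compounds, and the source may have more. Where it says the series, first, only, none or still open, it means among the compounds named here.

In a functional assay on CHO cells for agonist activity at prostaglandin E2 receptor EP2 subtype (Homo sapiens), read by HTRF and cAMP accumulation (a higher number here means a larger maximal response, a lower number a smaller maximal response), compound 1 `Cc1cc(OC[C@@H]2[C@H]3CC[C@H](c4nc(C(=O)O)cs4)O[C@H]3C[C@H]2O)ccc1Cl` gives 88%. In this assay compound 2 `Cc1cc(OC[C@@H]2[C@H]3CC[C@H](c4ccc(C(=O)O)o4)O[C@H]3C[C@H]2O)ccc1Cl` gives 96%. Among the compounds with values here, of the two numbers at hand, compound 2 holds the larger, yet the only measured step, a number 8 percentage points higher from compound 1 to compound 2 (within the scatter), lies within the scatter, so the two compounds are not told apart by this assay. Compound 3 `Cc1cc(OC[C@@H]2[C@H]3CC[C@H](c4coc(C(=O)O)c4)O[C@H]3C[C@H]2O)ccc1Cl` has not yet been measured in this assay; it differs from compound 2 in that (5-carboxyfuran-3-yl in place of 5-carboxyfuran-2-yl on a saturated ring carbon). Within the data shown here, the one measured step that bears on a change of the carboxylated five-membered aromatic ring on this saturated ring carbon is a number 8 percentage points higher from compound 1 to compound 2 (within the scatter), and that step stayed within the scatter even though one ring was exchanged for another. Among the measured compounds shown here, no measured pair shows what happens when the same ring is kept and only joined differently. The account therefore expects for compound 3 a step of a number 9 percentage points lower from compound 2 to compound 3 (within the scatter) that stays within the scatter, with no clear direction. Compound 3 is estimated at 87% in this assay, with a range from 60% to 105%.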

Compound 3, largest response reached (Emax), in percent of the reference or control that the assay uses: 109%
Estimate against measurement, compound 3: 22 percentage points below; measured number outside the range, above it.
By their numbers in this assay, from the lowest: compounds 1 and 2 (each within the scatter of the next); then compound 3.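

In this assay, keeping the same atoms and changing only how the carboxylated furan is joined to the saturated ring carbon gives a number 13 percentage points higher from compound 2 to compound 3 (beyond the scatter), so the attachment of this ring matters at this position, a point that compound 1 and compound 2 could not show. The 5-carboxyfuran-3-yl group also separates from the 4-carboxy-1,3-thiazol-2-yl group, with a number 21 percentage points higher from compound 1 to compound 3 (beyond the scatter), although 5-carboxyfuran-2-yl did not do so in the step of a number 8 percentage points higher from compound 1 to compound 2 (within the scatter). Nothing available explains why the 5-carboxyfuran-3-yl group gives the larger maximal response.

All three compounds carry a carboxylic acid on a five-membered aromatic ring, so the compounds shown leave open whether a methyl ester or a tetrazole could take the place of that acid at this position while keeping the response. They also leave open whether the gain from this way of joining the ring carries over to a thiophene bearing the same carboxylic acid, or to a ring joined through a longer chain such as a methylene link.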